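The source may hold more compounds than are shown below. What is called first, only, known or untested is meant among the compounds shown, and "the series" means these compounds.

Series of hydrazones on a shared core, tested in an ADME assay on Vero cells (Chlorocebus sabaeus) for cytotoxicity, read by microscopy (on this read-out lower numbers stand for higher toxicity in this test and higher numbers for lower toxicity in this test), for cytotoxicity toward Vero cells.

Compound 1 `O=C(N/N=C/c1ccc(Cl)cc1)c1cccnc1` carries a chloro on the aromatic ring. In this assay compound 1 gives > 100 ug/mL, which is a limit of the assay rather than a number. Compound 2 `O=C(N/N=C/c1ccccc1[N+](=O)[O-])c1cccnc1` carries a nitro on the same ring. In this assay compound 2 gives > 100 ug/mL, again a limit and not a number. Going by the values given here, both values sit at the limit of > 100 ug/mL in this assay, at which 2 of the 2 values shown sit, so no measured step can be drawn between them.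

Compound 3 `O=C(N/N=C/c1ccc([N+](=O)[O-])cc1)c1cccnc1` is the next candidate. Relative to compound 1 it differs by nitro in place of chloro on an aromatic carbon. With both measured values parked at the limit, no step size beyond the scatter is expected in this assay; the most likely outcome for compound 3 is a further limit. The expected step is a step that the limit leaves unreadable from compound 1 to compound 3. The estimate for compound 3 in this assay is 120 ug/mL, with a range from 50 ug/mL to 300 ug/mL.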

Compound 3, minimum cytotoxic concentration: >= 0.8 ug/mL
Compound 3 was reported as a limit (the forecaster's own chance of this, stated with the estimate: 80%); the middle value is on the limit's open side.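

Compound 1 and compound 3 are both reported only as limits in this assay, and no new step can be read between them. The compounds shown leave open whether nitro in place of chloro on an aromatic carbon shifts this read-out at all, and by how much.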